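Vinyl-to-methyl exchange on the pyrimidinyl alkyne

The compounds below may be only part of what the source reports. "The series", "measured", "known", "first", "only" and "open" are said of these compounds alone.

Compound 2 `C=Cc1nccc(C#Cc2ccc3ncn(-c4ccnc(N)n4)c3c2)n1` is measured in an assay on Sf9 cells for inhibition of mitogen-activated protein kinase kinase kinase 14 variant S549D (Homo sapiens), with a stated time of 30 min, in the presence of a further agent that is not named here (on this read-out higher numbers stand for weaker inhibition and lower numbers for stronger inhibition), and gives 39800 nM. Its nearest neighbour is compound 1 `C=Cc1cc(C#Cc2ccc3ncn(-c4ccnc(N)n4)c3c2)ccn1`, which in this assay gives 20000 nM; the only measured step, a 2.0-fold higher number from compound 1 to compound 2 (0.30 log units; within the scatter), lies within the scatter, so the two compounds stand together on the numbers shown and neither can be called weaker or stronger.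

Compound 3 `Cc1ccnc(C#Cc2ccc3ncn(-c4ccnc(N)n4)c3c2)n1` is not yet measured. Its difference from compound 2 is a group of 7 heavy atoms (5 carbon, 2 nitrogen; one six-membered aromatic ring with 2 hetero atoms) in place of a group of 8 heavy atoms (6 carbon, 2 nitrogen; one six-membered aromatic ring with 2 hetero atoms), on a triple-bonded carbon. Among the compounds with values here, the one measured step concerns a different exchange, a ring with two hetero atoms in place of a ring with one hetero atom on the triple-bonded carbon, and it stayed within the scatter; no measured step concerns the 4-methylpyrimidin-2-yl group itself. There is therefore no basis in the series for expecting movement beyond the scatter, and the step from compound 2 to compound 3 is estimated as a 1.0-fold higher number from compound 2 to compound 3 (0.00 log units; within the scatter). In this assay compound 3 is expected to give 40000 nM, with a range from 15000 nM to 110000 nM.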

Compound 3, half-maximal inhibitory concentration: 1580 nM
For compound 3 the middle estimate is 25-fold (1.40 log units) above the measured one; measured number outside the range, below it.
By their numbers in this assay, from the lowest: compound 3; then compounds 1 and 2 (each within the scatter of the next).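

In this assay, the group on the triple-bonded carbon can shift the number well beyond the scatter: 4-methylpyrimidin-2-yl gives a 25-fold lower number from compound 2 to compound 3 (1.40 log units; beyond the scatter) and a 13-fold lower number from compound 1 to compound 3 (1.10 log units; beyond the scatter), whereas the earlier exchange between the two vinyl-bearing groups gave only a 2.0-fold higher number from compound 1 to compound 2 (0.30 log units; within the scatter). A six-membered aromatic ring with 2 hetero atoms is therefore not enough on its own to give the lower number, since compound 2 carries such a ring and stays with compound 1, while compound 3, at 1580 nM, stands apart from both. The compounds shown offer no evidence for why this exchange has so large an effect.

The exchange replaces the whole group in one step, so the series cannot yet separate the contribution of the methyl from that of the rest of the 4-methylpyrimidin-2-yl group. Also open, from the compounds shown here alone, is whether the number holds or moves further when an ethyl group, a methoxy group or an amine stands in place of that methyl on the same ring.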